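Aminopyridine series: aryl replacement at the core

The source may hold more compounds than are shown below. What is called first, only, known or untested is meant among the compounds shown, and "the series" means these compounds.

Measured so far:
- compound 1 `CCOc1cccnc1Nc1cccc(C(=O)OC)n1`: 6200 nM
- compound 2 `COc1cccnc1Nc1cccc(C)n1`: 458 nM
- compound 3 `CCOc1cc(-c2ccccc2C#N)cnc1Nc1cccc(C)n1`: 37 nM

All three values come from an assay on Ltk cells with metabotropic glutamate receptor 5 (Homo sapiens) as the target, read by fluorescence and calcium flux; on this read-out higher numbers stand for weaker inhibition and lower numbers for stronger inhibition. Compound 1 gives 6200 nM and compound 2 gives 458 nM, while compound 3 gives 37 nM in this assay. Compound 3 thus carries the lowest number of the three; its gap to compound 2 is beyond the scatter, and the gap to compound 1 is wider still, also beyond the scatter. Within the data shown here, no two of the measured compounds differ in only one place, so no single measured step can be isolated from these numbers.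

Compound 4 `CCOc1cc(-c2cnccc2C)cnc1Nc1cccc(C)n1` has not been measured. It differs from compound 3 in one place: 4-methylpyridin-3-yl in place of 2-cyanophenyl on an aromatic carbon. The aromatic group attached at that carbon changes, but nothing else in the shared core moves. Among the measured compounds shown here, there is no measured pair that isolates a comparable change, so the expectation rests on compound 3 alone and is held loosely.

The estimate for compound 4 is a modest weakening relative to compound 3, as a step of a 1.9-fold higher number from compound 3 to compound 4 (0.28 log units; within the scatter) in this assay. Compound 4 is expected at 70 nM, within a range of 20 nM to 250 nM.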

Compound 4, half-maximal inhibitory concentration: 45 nM
For compound 4 the middle estimate is 1.6-fold (0.19 log units) above the measured one, within the range that was stated.
By their numbers in this assay, from the lowest: compounds 3 and 4 (each within the scatter of the next); then compound 2; then compound 1.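

In this assay, 4-methylpyridin-3-yl in place of 2-cyanophenyl gives a 1.2-fold higher number from compound 3 to compound 4 (0.09 log units; within the scatter), so this read-out does not separate the two groups at this carbon. Among these compounds, this is the first step confined to one place, and it shows that the aromatic carbon two atoms from the ring nitrogen, para to the (6-methylpyridin-2-yl)amino group, accepts both a six-membered aromatic ring of carbon only bearing a nitrile and a six-membered aromatic ring with a hetero atom bearing a methyl, with no step beyond the scatter. The nitrile and the ring carbon are exchanged together in this pair, so neither part of the change can be read alone, and no measurement available here accounts for the result.

Compound 1 and compound 2 each differ from compound 3 and compound 4 in more than one place, so what an aromatic group at this carbon contributes on its own stays unread. Also open, from the compounds shown here alone, is what a non-aromatic group at the same carbon would give, such as a morpholine or a carboxylic acid.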